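A Fluorocyclopropyl Amide With the Other Stereochemistry

The compounds below may be only part of what the source reports. "The series", "measured", "known", "first", "only" and "open" are said of these compounds alone.

Compound 1 `CCC(=O)N1CC2CC(C1)N2` gives 490 nM in an assay on SH-EP1 cells for agonist activity at Neuronal acetylcholine receptor; alpha4/beta2 (Homo sapiens), read by FLIPR and calcium flux; a higher number here means that more compound is needed for the effect, a lower number that less compound is needed. Among the three measured compounds it stands second highest: compound 3 `O=C([C@@H]1C[C@@H]1F)N1CC2CC(C1)N2` gives 120 nM, while compound 2 `O=C(C1CC=CC1)N1CC2CC(C1)N2` gives 6600 nM. Compound 4 `O=C([C@H]1C[C@@H]1F)N1CC2CC(C1)N2` differs from compound 1 in one place: 2-fluorocyclopropyl in place of ethyl on a carbonyl carbon. For the measured compounds named here, the only measured step that bears on this change is the one in which the same group enters with the other arrangement of its two stereocentres: a 4.1-fold lower number from compound 1 to compound 3 (0.61 log units; beyond the scatter). That step was modest and downward. The other arrangement need not repeat it, so a smaller downward step is expected, close to the scatter. Compound 4 is therefore expected to give 300 nM, between 90 nM and 1200 nM, which means a 1.6-fold lower number from compound 1 to compound 4 (0.21 log units; within the scatter).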

Compound 4, half-maximal effective concentration: 850 nM
Compound 4: middle estimate off by 2.8-fold (0.45 log units), on the low side, and the stated range covers the measured number.
By their numbers in this assay, from the lowest: compound 3; then compounds 1 and 4 (each within the scatter of the next); then compound 2.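

The 2-fluorocyclopropyl group on this carbonyl carbon does not lower the number by itself: in this arrangement, replacing ethyl gives a 1.7-fold higher number from compound 1 to compound 4 (0.24 log units; within the scatter). Changing one stereocentre at a saturated ring carbon gives a 7.1-fold higher number from compound 3 to compound 4 (0.85 log units; beyond the scatter), so the drop seen earlier belongs to one arrangement of the group, not to the group alone. One caution applies to this comparison: the fact that one of compounds 3 and 4 is drawn with a defined configuration and the other without, at the place where they differ

On these data alone, what a plain cyclopropyl group or a longer chain such as butyl would give on this carbonyl carbon remains open. As far as these compounds go, the part played by the fluorine also remains open.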